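Cyclopropyl in Place of Chloro on the Shared Core

The source may hold more compounds than are shown below. What is called first, only, known or untested is meant among the compounds shown, and "the series" means these compounds.

Compound 3 `Cc1ccc([N+](=O)[O-])cc1S(=O)(=O)N(C)/N=C/c1cnn2ccc(Cl)cc12` gives 390 nM in an assay on isolated protein for inhibition of phosphatidylinositol 4,5-bisphosphate 3-kinase catalytic subunit beta isoform (Homo sapiens), read by 33P incorporation, with a stated time of 60 min (on this read-out lower numbers stand for stronger inhibition and higher numbers for weaker inhibition), and is the only one of the three measured compounds to return a number rather than a limit. Compound 1 `Cc1ccc([N+](=O)[O-])cc1S(=O)(=O)N(C)/N=C/c1cnn2ccccc12` returns > 10000 nM in this assay, which is a limit of the assay. Compound 2 `COc1ccn2ncc(/C=N/N(C)S(=O)(=O)c3cc([N+](=O)[O-])ccc3C)c2c1` returns > 1000 nM in this assay, likewise a limit. The step of an at least 25-fold lower number from compound 1 to compound 3 (1.40 log units; beyond the scatter) and the step of an at least 2.5-fold lower number from compound 2 to compound 3 (0.40 log units; beyond the scatter) both end at compound 3, so the chloro on the shared core goes with the lowest number shown, though how far beyond their limits compound 1 and compound 2 lie cannot be read. Compound 4 `Cc1ccc([N+](=O)[O-])cc1S(=O)(=O)N(C)/N=C/c1cnn2ccc(C3CC3)cc12` differs from compound 3 by cyclopropyl in place of chloro on an aromatic carbon. For the measured compounds named here, no measured step exchanges the chloro for another carbon group; the two steps into compound 3 show only that hydrogen or methoxy at that carbon gives a weaker result. The cyclopropyl is expected to act much like the chloro, so the expected step of a 1.0-fold higher number from compound 3 to compound 4 (0.01 log units; within the scatter) should be within or close to the scatter. Compound 4 is therefore estimated at 400 nM, with a range of 120 nM to 1300 nM.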

Compound 4, half-maximal inhibitory concentration: > 1000 nM
Compound 4 gave a limit, no number; the forecaster's own chance of this, stated with the estimate: 10%; at least 2.5-fold (0.39 log units) between middle value and limit.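

For the compounds shown here, exchanging the chloro for cyclopropyl at this carbon, opposite the ring nitrogen, gives an at least 2.5-fold higher number from compound 3 to compound 4 (0.40 log units; beyond the scatter) in this assay, the first measured step here that replaces the chloro with a carbon group. Going by these compounds alone, the earlier steps showed only that hydrogen and methoxy fall short of the chloro; cyclopropyl now falls short as well, so the chloro remains the only one of these four groups at this carbon to return a number. The steps from compound 1 and compound 2 to compound 4 cannot be read, since both ends of each are limits, and the shared limit is a crowded one: the limit of > 1000 nM in this assay, at which 2 of the 4 values shown sit.

From the compounds shown here alone, how hydrogen, methoxy and cyclopropyl rank against one another at this carbon stays open. Also open, going by these compounds, is whether a methyl, a bromo or a nitrile there would match the chloro.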